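This account rests on a few compounds, and the source may have more. Where it says the series, first, only, none or still open, it means among the compounds named here.

Three compounds have been measured in a functional assay on PC-3 cells (Homo sapiens) for cytotoxicity, read by MTT assay, with a stated time of 72 h; on this read-out lower numbers stand for stronger inhibition of growth and higher numbers for weaker inhibition of growth:

compound 1 `O=C(Nc1ccc([Se][Se]c2ccc(NC(=O)OCc3ccccc3)cc2)cc1)OCc1ccccc1` gives 33500 nM
compound 2 `N#C[Se]c1ccc(NC(=O)Oc2ccc(F)cc2)cc1` gives 40400 nM
compound 3 `O=C(Nc1ccc([Se][Se]c2ccc(NC(=O)OCc3ccc([N+](=O)[O-])cc3)cc2)cc1)OCc1ccc([N+](=O)[O-])cc1` gives 27100 nM

Compound 2 holds the highest of the three numbers, yet its distance to compound 1 and to compound 3 lies within the scatter of repeated measurements, so the three cannot be told apart on this read-out.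

Compound 4 `N#C[Se]c1ccc(NC(=O)Oc2ccc(Cl)cc2)cc1` shares its core with compound 2 and differs from it only by chloro in place of fluoro on an aromatic carbon. No measured pair among these compounds shows this kind of exchange, so there is no step to lean on; the change is expected to leave the result in this assay unmoved beyond the scatter. Compound 4 is therefore estimated at 35000 nM, within a range from 17000 nM to 75000 nM. The step that this estimate means is expected to be a 1.2-fold lower number from compound 2 to compound 4 (0.06 log units; within the scatter).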

Compound 4, concentration for total growth inhibition: 18700 nM
For compound 4 the middle estimate is 1.9-fold (0.27 log units) above the measured one, and the stated range covers the measured number.
By their numbers in this assay, from the lowest: compounds 4, 3, 1 and 2 (each within the scatter of the next, the first and the last beyond it).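

In this assay the exchange of fluoro for chloro on an aromatic carbon, para to a large group, gives a 2.2-fold lower number from compound 2 to compound 4 (0.33 log units; beyond the scatter) and is the first step among these compounds that can be read at all. It shows that this position responds to the halogen it carries, though only modestly. Nothing at hand explains the difference.

The compounds shown leave open whether bromo would carry the step further. On these data alone, it also remains open how an amine or a methoxy group would behave at this position.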